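Isopropyl to isobutyl at the ketone of compound 3

The source may hold more compounds than are shown below. What is called first, only, known or untested is meant among the compounds shown, and "the series" means these compounds.

Compound 3 `Cc1cc(C(=O)O)ccc1OCCCCOc1ccc(C(=O)C(C)C)c(O)c1C` gives 25.2% in an assay on HEK293 cells for positive allosteric modulation of metabotropic glutamate receptor 3 (Rattus norvegicus), read by thallium flux, with a stated time of 2.5 min (a higher number here means a larger maximal response, a lower number a smaller maximal response), and is the lowest of the three numbers in hand. Compound 2 `Cc1c(OCCCCOc2ccc(C(=O)O)cc2)ccc(C(=O)CC(C)C)c1O` gives 51.9% and compound 1 `COc1cc(C(=O)O)ccc1OCCCCOc1ccc(C(=O)CC(C)C)c(O)c1C` gives 73.9%, each standing above compound 3 by more than the scatter. Among the measured compounds shown here, the only measured step is a number 22 percentage points lower from compound 1 to compound 2 (beyond the scatter); it is a change at an aromatic carbon and does not touch the ketone. Compound 4 `Cc1cc(C(=O)O)ccc1OCCCCOc1ccc(C(=O)CC(C)C)c(O)c1C` differs from compound 3 by isobutyl in place of isopropyl on a carbonyl carbon. For the measured compounds named here, no measured step covers this change, so its size cannot be read off directly. What the values do show is that both compounds carrying isobutylcarbonyl, compound 1 and compound 2, sit well above compound 3, which carries isopropylcarbonyl; compound 2 shares the isobutylcarbonyl of compound 4 and is otherwise close to it. On that footing an upward step in this assay is expected for compound 4, estimated at a number 24.8 percentage points higher from compound 3 to compound 4 (beyond the scatter). The estimate for compound 4 is 50%, with a range from 32% to 68%. This rests on compound 2, which gives 51.9% with the same ketone, set against compound 3 at 25.2%.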

Compound 4, largest response reached (reported as percent of maximum), in percent of the reference or control that the assay uses: 42.1%
The estimate for compound 4 lay 7.9 percentage points above the measured number; measured number inside the range.
By their numbers in this assay, from the lowest: compound 3; then compounds 4 and 2 (each within the scatter of the next); then compound 1.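

In this assay, among the compounds shown here, the first direct reading at the ketone is a number 16.9 percentage points higher from compound 3 to compound 4 (beyond the scatter) for isobutyl in place of isopropyl on a carbonyl carbon, so this position responds to a single added carbon with the rest of the core held fixed. With isobutylcarbonyl kept constant, methyl in place of hydrogen on an aromatic carbon gives a number 9.8 percentage points lower from compound 2 to compound 4 (within the scatter) and so is not resolved, while methyl in place of methoxy gives a number 31.8 percentage points lower from compound 1 to compound 4 (beyond the scatter) as the largest of the new steps. Read with a number 22 percentage points lower from compound 1 to compound 2 (beyond the scatter), this sets methoxy apart from both methyl and hydrogen at that aromatic carbon, and compound 1 keeps the highest number of the four.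

Open, from the compounds shown here alone, is whether a longer chain or a cyclopropyl on the carbonyl carbon would extend the ketone trend beyond two points, and whether the isopropyl to isobutyl step keeps its size when methoxy replaces methyl on the aromatic carbon. Nothing available here bears on the reason for the size of any of these steps.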